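Benzimidazolyl for Bromophenyl on a Triazole Nitrogen

The source may hold more compounds than are shown below. What is called first, only, known or untested is meant among the compounds shown, and "the series" means these compounds.

Compound 1, `CN(CCNCc1cn(-c2ccc(Cl)cc2)nn1)CCNc1ccnc2cc(Cl)ccc12`, gives 9500 nM in a functional assay on HCC827 cells (Homo sapiens) for antiproliferative activity, read by sulforhodamine B assay, with a stated time of 72 h; a lower number here means a stronger inhibitor, a higher number a weaker inhibitor. Compound 2, `CN(CCNCc1cn(-c2ccc(Br)cc2)nn1)CCNc1ccnc2cc(Cl)ccc12`, gives 11000 nM in this assay, a step of a 1.2-fold higher number from compound 1 to compound 2 (0.06 log units; within the scatter). On these two numbers compound 2 holds the higher value, though its gap to compound 1 lies within the scatter, so the two are indistinguishable here.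

Compound 3, `CN(CCNCc1cn(-c2nc3ccccc3[nH]2)nn1)CCNc1ccnc2cc(Cl)ccc12`, differs from compound 2 by 1H-benzimidazol-2-yl in place of 4-bromophenyl on an aromatic nitrogen. Going by the values given here, the only measured step, the halogen swap from compound 1 to compound 2, touches the same position but exchanges one halogen for another, which bears little on an exchange of a whole aryl group for a fused bicyclic heteroaryl group. Among the compounds with values here, no measured pair shows what such a change does in this assay, so the expectation for compound 3 rests on compound 2 alone, with a wide range in both directions.

Compound 3 is therefore estimated at 9000 nM in this assay, with a range from 2500 nM to 30000 nM, meaning an expected step of a 1.2-fold lower number from compound 2 to compound 3 (0.09 log units; within the scatter) that stays within the scatter.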

Compound 3, half-maximal inhibitory concentration: 32000 nM
Estimate against measurement, compound 3: 3.6-fold (0.55 log units) below; measured number outside the range, above it.
By their numbers in this assay, from the lowest: compounds 1 and 2 (each within the scatter of the next); then compound 3.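

Going by these compounds alone, on the aromatic nitrogen of the five-membered aromatic ring with 3 nitrogen, 1H-benzimidazol-2-yl in place of 4-bromophenyl gives the first change at this position that lies beyond the scatter in this assay, a 2.9-fold higher number from compound 2 to compound 3 (0.46 log units; beyond the scatter), and the exchange for 4-chlorophenyl reads much the same, a 3.4-fold higher number from compound 1 to compound 3 (0.53 log units; beyond the scatter). The halogen swap had left the number within the scatter, a 1.2-fold higher number from compound 1 to compound 2 (0.06 log units; within the scatter), so the position proved insensitive to that exchange but not to replacing the whole aryl group, and both steps point towards a weaker inhibitor, though only modestly. Nothing in the data at hand accounts for this shift or ties it to any property of the incoming group.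

The compounds shown leave open whether the higher number goes with the second ring itself or with the ring nitrogens and their hydrogen, a question that a 2-naphthyl group, with two rings of carbon only, or a 1-methylbenzimidazol-2-yl group could help to separate. They also leave open whether any group on this nitrogen, such as a 4-aminophenyl or a 3-pyridyl group, would give a lower number than the two halogen-bearing phenyl groups do.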